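A few compounds are considered here, and "the series" means these few. Any claim that something is new, unique, unknown or untested is made for them only; others in the source may bear on it.

Compound 1 `CNC1(COc2cccnc2)CC1` gives 3 nM in an assay on brain for displacement of a labelled ligand from Neuronal acetylcholine receptor; alpha4/beta2 (Rattus norvegicus); a lower number here means a stronger inhibitor, a higher number a weaker inhibitor. Its methyl-substituted counterpart, compound 2 `CN(C)C1(COc2cccnc2)CC1`, gives 95 nM; the two cores differ as follows: methyl in place of hydrogen on an amine nitrogen and the step is a 32-fold higher number from compound 1 to compound 2 (1.50 log units; beyond the scatter). Compound 3 `CNC1(COc2ccc(Br)nc2)CC1` gives 38.8 nM, so the change bromo in place of hydrogen on an aromatic carbon made the step of a 13-fold higher number from compound 1 to compound 3 (1.11 log units; beyond the scatter).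

Compound 4 `CN(C)C1(COc2cncc(Br)c2)CC1` carries the same kind of change on the core of compound 2: bromo in place of hydrogen on an aromatic carbon. The place is not identical, though: in compound 3 the bromo sits next to the ring nitrogen and para to a group of 7 heavy atoms, whereas in compound 4 it sits two atoms from the ring nitrogen and meta to a group of 8 heavy atoms. Going by the values given here, the step is expected to weaken binding, since the only bromo step seen, from compound 1 to compound 3, was large, but the differing place leaves the size uncertain; compound 4 is expected at a 5.3-fold higher number from compound 2 to compound 4 (0.72 log units; beyond the scatter) from compound 2, that is 500 nM (150 nM to 2000 nM).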

Compound 4, inhibition constant: 273 nM
Compound 4: middle estimate off by 1.8-fold (0.26 log units), on the high side; the range from low to high includes it.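

In this assay, bromo in place of hydrogen on an aromatic carbon gives a higher number on both cores, and on the core of compound 2 the step is a 2.9-fold higher number from compound 2 to compound 4 (0.46 log units; beyond the scatter). The direction carries over from one core to the other, but the size does not: the same change on two cores in this assay, a 13-fold higher number (1.11 log units; beyond the scatter) from compound 1 to compound 3 and a 2.9-fold higher number (0.46 log units; beyond the scatter) from compound 2 to compound 4, 4.5-fold (0.65 log units) apart, beyond the scatter of two such steps. The two steps differ in the place of the bromo as well as in the core, so this comparison cannot separate the two and does not show that the core alone sets the size.

On these data alone, it remains open how the step runs with the bromo at one and the same place on both cores. As far as these compounds go, it also remains open whether chloro or methoxy at these places would give a step in the same direction.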